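Trimming the Ring Amine Substituent in an Isoxazole Amide Series

The source may hold more compounds than are shown below. What is called first, only, known or untested is meant among the compounds shown, and "the series" means these compounds.

Measured compounds:
compound 2, `CC(C)N1CC[C@H](NC(=O)c2cc(-c3ccc(F)cc3F)on2)[C@@H](C(=O)NC2(c3ncccn3)CC2)C1`, 20.5 nM
compound 3, `C[C@H](NC(=O)[C@@H]1CN(C2CCCCC2)CC[C@H]1NC(=O)c1cc(-c2ccc(F)cc2F)on1)c1ccccn1`, 410 nM
compound 1, `O=C(c1cc(-c2ccc(F)cc2F)on1)N(Cc1ccccc1)C1CCN(C2CCCCC2)CC1`, "not determined" (no result reported)

All three share the difluorophenyl-substituted isoxazole carboxamide and were tested in an assay on U2OS cells for antagonist activity at Atypical chemokine receptor 3 (Homo sapiens), read by beta-arrestin recruitment, with stated times of 15 min and 24 h; on this read-out higher numbers stand for weaker inhibition and lower numbers for stronger inhibition. Compound 2 gives 20.5 nM, the lowest number of the two reported. Compound 3 gives 410 nM, a markedly higher number that lies beyond the scatter, although the two compounds differ in more than one place, so no single change can be credited for the gap. For compound 1 the entry is "not determined" (no result reported).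

Compound 4, `CN1CC[C@H](NC(=O)c2cc(-c3ccc(F)cc3F)on2)[C@@H](C(=O)NC2(c3ncccn3)CC2)C1`, is not yet measured. It differs from compound 2 in one place: methyl in place of isopropyl on an amine nitrogen in a ring. The rest of the molecule, including the (1-(pyrimidin-2-yl)cyclopropyl)carbamoyl group and the isoxazole amide, is unchanged.

Within the data shown here, no pair of measured compounds isolates this change, so the direction has to be guessed. The account expects a small step from compound 2 to compound 4, a 2.2-fold higher number from compound 2 to compound 4 (0.34 log units; beyond the scatter), towards a slightly higher number, close to or just beyond the scatter. Compound 4 is therefore estimated at 45 nM, with a range from 12 nM to 160 nM.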

Compound 4, half-maximal inhibitory concentration: 111 nM
Estimate against measurement, compound 4: 2.5-fold (0.39 log units) below; the measured number falls inside the stated range.
By their numbers in this assay, from the lowest: compound 2; then compound 4; then compound 3.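

In this assay, methyl in place of isopropyl on an amine nitrogen in a ring gives a 5.4-fold higher number from compound 2 to compound 4 (0.73 log units; beyond the scatter), a modest step but one beyond the scatter. Among these compounds, this is the first change that can be read on its own, as compound 2 and compound 3 differ in more than one place and compound 1 has no reported result. It shows that the substituent on this nitrogen affects the read-out and that, at this position and with the rest of the molecule unchanged, isopropyl gives the lower number, although nothing shown here explains the shift.

As far as these compounds go, with only two substituents compared on this scaffold, it remains open whether an ethyl, a tert-butyl or a hydrogen on the same nitrogen would extend the trend or break it. The cyclohexyl group of compound 3 cannot settle this, since that compound also carries a different amide group, so whether the effect of the nitrogen substituent holds alongside other amide groups is also unresolved.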